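Two Hydrazone Adenosine Analogues and an Untested Third

This account rests on a few compounds, and the source may have more. Where it says the series, first, only, none or still open, it means among the compounds named here.

Measured so far in an assay on CHO-K1 cells for displacement of a labelled ligand from adenosine receptor A1 (Homo sapiens), read by scintillation counting, with a stated time of 60 min; a higher number here means a weaker inhibitor, a lower number a stronger inhibitor:
compound 1 `Nc1nc(N/N=C/c2cncs2)nc2c1ncn2[C@@H]1O[C@H](CO)[C@@H](O)[C@H]1O` gives 22 nM
compound 2 `Nc1nc(N/N=C/c2ccc(Br)cn2)nc2c1ncn2[C@@H]1O[C@H](CO)[C@@H](O)[C@H]1O` gives 4.7 nM

Within the data shown here, compound 2 stands at the lower of the two numbers, with a 4.7-fold lower number from compound 1 to compound 2 (0.67 log units; beyond the scatter) the only step seen. Compound 3 `CN(C)c1ccc(/C=N/Nc2nc(N)c3ncn([C@@H]4O[C@H](CO)[C@@H](O)[C@H]4O)c3n2)cc1` differs from compound 2 by 4-(dimethylamino)phenyl in place of 5-bromopyridin-2-yl on a carbon with a double bond to nitrogen. Among the measured compounds shown here, no measured step involves 4-(dimethylamino)phenyl, so only the step from compound 1 to compound 2 bears on it, and it bears only loosely. The step of a 1.9-fold higher number from compound 2 to compound 3 (0.28 log units; within the scatter) is therefore expected to be small. Compound 3 is estimated at 9 nM, within 2.5 nM to 35 nM.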

Compound 3, inhibition constant: > 10000 nM
Compound 3 was reported as a limit; the forecaster's own chance of this, stated with the estimate: 3%; at least 1100-fold (3.04 log units) between middle value and limit.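

In this assay compound 3 is reported only as a limit, not a number: the limit of > 10000 nM in this assay, at which 1 of the 3 values shown sits. On the carbon with a double bond to nitrogen, 4-(dimethylamino)phenyl gives an at least 2100-fold higher number from compound 2 to compound 3 (3.32 log units; beyond the scatter) and an at least 450-fold higher number from compound 1 to compound 3 (2.65 log units; beyond the scatter). This position can therefore do far more than shift the number modestly, as it did between the two earlier rings, each of which holds a hetero atom.

The compounds shown leave open whether the loss goes with the carbon-only ring or with the dimethylamino group. An unsubstituted phenyl group or a bromophenyl group would separate the two.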